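Exchange of the Ring Nitrogen Substituent: Expecting Compound 4

The source may report more compounds than this note shows. Statements on the series, on what has been measured and on what is new or still open speak of the compounds shown alone.

Measured compounds:
compound 1, `CN1CCN(c2ccc(Nc3ncc4nc(Nc5ccc(F)cc5)n(CCNS(=O)(=O)C5CC5)c4n3)cc2)CC1`: in a functional assay on A549 cells (Homo sapiens) for antiproliferative activity, read by MTT assay, with a stated time of 72 h (on this read-out higher numbers stand for weaker inhibition and lower numbers for stronger inhibition), compound 1 gives "not determined" (no result reported)
compound 2, `CN1CCN(c2ccc(Nc3ncc4nc(Nc5ccc(F)cc5)n([C@@H]5CCCN(C(=O)CO)C5)c4n3)cc2)CC1`: in this assay compound 2 gives "not determined" (no result reported)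
compound 3, `CN1CCN(c2ccc(Nc3ncc4nc(Nc5ccc(F)cc5)n([C@@H]5CCN(S(=O)(=O)C6CC6)C5)c4n3)cc2)CC1`: in this assay compound 3 gives > 10000 nM

Only compound 3 carries a result, and it is a limit of this assay rather than a number: compound 3 gives > 10000 nM, the limit described in the limit of > 10000 nM in this assay, at which 1 of the 3 values shown sits. Among the measured compounds shown here, compounds 1 and 2 have no reported result, so no step between measured compounds can be read.

Compound 4, `CN1CCN(c2ccc(Nc3ncc4nc(Nc5ccc(F)cc5)n(-c5cccc(NC(=O)CO)c5)c4n3)cc2)CC1`, differs from compound 3 by 3-(((hydroxymethyl)carbonyl)amino)phenyl in place of 1-(cyclopropylsulfonyl)pyrrolidin-3-yl on an aromatic nitrogen. For the measured compounds named here, with no measured pair to guide the direction, the expected step in this assay is an at least 2.5-fold lower number from compound 3 to compound 4 (0.39 log units; beyond the scatter), a gain toward stronger inhibition but with low confidence. Compound 4 is therefore estimated at 4000 nM, within 500 nM to 30000 nM, and a limit result remains quite possible.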

Compound 4, half-maximal inhibitory concentration: 1510 nM
Compound 4: the middle estimate sits 2.6-fold (0.42 log units) above what was measured; measured number inside the range.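

The substituent on the aromatic nitrogen does move the read-out in this assay: 3-(((hydroxymethyl)carbonyl)amino)phenyl in place of 1-(cyclopropylsulfonyl)pyrrolidin-3-yl gives an at least 6.6-fold lower number from compound 3 to compound 4 (0.82 log units; beyond the scatter). The result for compound 3 is a limit, so the full size of this step cannot be read: the limit of > 10000 nM in this assay, at which 1 of the 4 values shown sits.

The compounds shown leave open whether the phenyl ring or its (hydroxymethyl)carbonyl amino group accounts for the change, since both enter together. They also leave open how an amine or a carboxylic acid on that phenyl ring would compare.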